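A few compounds are considered here, and "the series" means these few. Any claim that something is new, unique, unknown or untested is made for them only; others in the source may bear on it.

Measured so far in a physicochemical assay for metabolic stability, in simulated intestinal fluid, with a stated time of 15 min, tested at 4 uM; on this read-out lower numbers stand for a less stable compound and higher numbers for a more stable compound:
Compound 1 `COC[C@H](NC(=O)c1cc(OC)no1)C(=O)N[C@@H](COC)C(=O)N[C@@H](CC(C)C)C(=O)[C@@]1(C)CO1`: 35%
Compound 2 `COC[C@H](NC(=O)c1cc(C)on1)C(=O)N[C@@H](CC(C)C)C(=O)N[C@@H](CC(C)C)C(=O)[C@@]1(C)CO1`: 90%

Compound 2 holds the higher of these two numbers. Its gap to compound 1 lies beyond the scatter of repeated measurements. The next compound to be tested, compound 3 `COC[C@H](NC(=O)c1cc(C)on1)C(=O)N[C@@H](COC)C(=O)N[C@@H](CC(C)C)C(=O)[C@@]1(C)CO1`, has no number yet. It departs from compound 2 at one place: methoxy in place of isopropyl on a saturated chain carbon, two bonds along the chain from an amide-type nitrogen and a carbonyl carbon. In words, this puts methoxy in place of isopropyl on a saturated chain carbon, two bonds along the chain from an amide-type nitrogen and a carbonyl carbon. Cut one bond further out, the same difference reads isobutyl to methoxymethyl.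

Among the measured compounds shown here, no two measured compounds differ in one place alone, so no measured step gives the size of this change directly. The expectation is therefore tentative: a lower number in this assay, by a margin beyond the scatter. For the measured compounds named here, it leans on compound 1 at 35%, the only lower value measured so far. The expected step is a number 30 percentage points lower from compound 2 to compound 3 (beyond the scatter). For compound 3 the estimate is 60%, with an expected range from 35% to 88%.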

Compound 3, percent of the compound remaining: 70%
For compound 3 the middle estimate is 10 percentage points below the measured one, within the range that was stated.
By their numbers in this assay, from the lowest: compound 1; then compound 3; then compound 2.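

In this assay the saturated chain carbon, two bonds along the chain from an amide-type nitrogen and a carbonyl carbon, proves sensitive to its substituent: methoxy in place of isopropyl, which reads as isobutyl to methoxymethyl when cut one bond further out, gives a number 20 percentage points lower from compound 2 to compound 3 (beyond the scatter) and counts as a modest step. Among the compounds shown here, with compound 3 in hand, the group on the carbonyl carbon can also be read alone for the first time, as 5-methyl-1,2-oxazol-3-yl in place of 3-methoxy-1,2-oxazol-5-yl gives a number 35 percentage points higher from compound 1 to compound 3 (beyond the scatter) and counts as a large step. These two single changes now have separate sizes in this assay, although no measurement at hand explains either of them.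

The compounds shown leave open how an amine, a carboxylic acid or a longer chain such as n-butyl would read at the same chain carbon. They also leave open whether isobutyl to methoxymethyl would give a step of similar size with 3-methoxy-1,2-oxazol-5-yl on the carbonyl carbon, since the isobutyl partner of compound 1 is not among them.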